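A few compounds are considered here, and "the series" means these few. Any claim that something is new, unique, unknown or untested is made for them only; others in the source may bear on it.

In a functional assay on MSTO-211H cells (Homo sapiens) for inhibition, read by trypan blue exclusion, with a stated time of 72 h (a lower number here means a stronger inhibitor of growth, a higher number a weaker inhibitor of growth), compound 1 `CCCn1c(-c2ccc(O)cc2)c(C)c2ccccc21` gives 7100 nM. Compound 2 `CCCn1c(-c2ccc(O)c(O)c2)c(C)c2cc(O)ccc21` stands at a limit of the assay, > 20000 nM. Compound 3 `Cc1c(-c2ccc(O)c(O)c2)n(CCCCOc2ccccc2)c2ccc(O)cc12` gives 3400 nM, the lower of the two true numbers and beyond the scatter from compound 1. Going by the values given here, the one measured step, an at least 5.8-fold lower number from compound 2 to compound 3 (0.76 log units; beyond the scatter), brings phenoxymethyl in place of hydrogen on a saturated chain carbon. Its size is a bound rather than a number, and it lies at a different place from the change considered next.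

Compound 4 `Cc1c(-c2ccc(O)cc2)n(CCCCOc2ccccc2)c2ccc(O)cc12` keeps that chain but has hydrogen in place of hydroxy on an aromatic carbon, 3,4-dihydroxyphenyl to 4-hydroxyphenyl: hydrogen in place of hydroxy on an aromatic carbon. Among the compounds with values here, no measured step isolates this change. Compound 1 also carries 4-hydroxyphenyl and compound 2 carries 3,4-dihydroxyphenyl, but these two also differ elsewhere, and their values show only a number against a limit. A small lean toward a lower number is therefore all that can be expected, with nothing beyond the scatter. The expected step is a 1.2-fold lower number from compound 3 to compound 4 (0.08 log units; within the scatter). For compound 4 the estimate is 2800 nM, with an expected range of 1100 nM to 7000 nM.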

Compound 4, concentration for 50% growth inhibition: 2900 nM
For compound 4 the middle estimate is 1.0-fold (0.02 log units) below the measured one, and the stated range covers the measured number.
By their numbers in this assay, from the lowest: compounds 4 and 3 (each within the scatter of the next); then compound 1. At a limit, above all of these: compound 2.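

In this assay, going by these compounds alone, the change from 3,4-dihydroxyphenyl to 4-hydroxyphenyl gives a 1.2-fold lower number from compound 3 to compound 4 (0.07 log units; within the scatter) and so has, for the first time, a size that can be read as a number. Within the data shown here, on the chain shared by these two compounds, the hydroxy ortho to a hydroxy group can therefore give way to hydrogen with no change that this assay can tell apart, whereas the earlier compounds offered only a number against a limit, and those two differ elsewhere as well. Nothing given here bears on a cause for this flat step.

As far as these compounds go, whether the same change stays as flat with the shorter chain of compound 1 remains open. Also open, from the compounds shown here alone, is what a methoxy group, a fluorine atom or an amine would do at this place on the ring.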